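Can a methylsulfonyl group bring a measurable value?

A few compounds are considered here, and "the series" means these few. Any claim that something is new, unique, unknown or untested is made for them only; others in the source may bear on it.

Measured in an ADME assay on Raji cells (Homo sapiens) for cytotoxicity, read by luminescence, with a stated time of 72 h; a lower number here means that less compound is needed, a higher number that more compound is needed for the effect:
Compound 1 `CCOC(=O)c1c(-c2cccc(C)c2)[nH]c2cc(OC)ccc2c1=O`: > 21500 nM (a limit)
Compound 2 `CCOC(=O)c1c(-c2cccc(OC(F)(F)F)c2)[nH]c2cc(OC)ccc2c1=O`: > 21500 nM (a limit)

Neither entry is a true number. Compound 2 stands at > 21500 nM, which is a limit of the assay. The same holds across the small set so far: the limit of > 21500 nM in this assay, at which 2 of the 2 values shown sit.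

The next compound is compound 3 `CCOC(=O)c1c(-c2cccc(S(C)(=O)=O)c2)[nH]c2cc(OC)ccc2c1=O`. It has methylsulfonyl in place of trifluoromethoxy on an aromatic carbon, meta to a large group, and the rest of the structure is unchanged: methylsulfonyl in place of trifluoromethoxy on an aromatic carbon.

Going by the values given here, the one measured step that bears on this is a step that the two limits leave unreadable from compound 1 to compound 2. It also exchanges a group on an aromatic carbon, but it gives no size to build on. No step beyond the scatter is therefore expected in this assay, and no direction can be given. The most likely result is another limit, not a number. The expected step is a step that the limit leaves unreadable from compound 2 to compound 3.

Compound 3 is estimated at 30000 nM, with an expected range from 12000 nM to 60000 nM.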

Compound 3, half-maximal effective concentration: > 21500 nM
Compound 3 gave a limit, no number; the forecaster's own chance of this, stated with the estimate: 85%; the middle value does not contradict the limit.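

No step can be read between compound 1, compound 2 and compound 3, because all three entries are the same limit rather than true numbers: the limit of > 21500 nM in this assay, at which 3 of the 3 values shown sit.

The compounds shown leave open whether any group at this place on the shared core gives a true number in this assay, and how methyl, trifluoromethoxy and methylsulfonyl would then compare.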